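Removing the benzoyl group from compound 1

The source may report more compounds than this note shows. Statements on the series, on what has been measured and on what is new or still open speak of the compounds shown alone.

Series notes, a functional assay on T98G cells (Homo sapiens) for cytotoxicity, read by MTT assay, with a stated time of 48 h; on this read-out higher numbers stand for weaker inhibition and lower numbers for stronger inhibition. For the measured compounds named here, compound 1 `O=C(O[C@H]1C[C@H](n2cc(F)c(=O)[nH]c2=O)O[C@@H]1COP(=O)(O)Oc1ccc2ncccc2c1)c1ccccc1` gives 1300 nM, the lowest of the three numbers measured so far. Compound 3 `C[N+]1(C)CCC(OP(=O)([O-])OC[C@H]2O[C@@H](n3cc(F)c(=O)[nH]c3=O)C[C@@H]2OC(=O)c2ccccc2)CC1` gives 6700 nM, and compound 2 `CCOC(=O)C[n+]1cccc2cc(OP(=O)([O-])OC[C@H]3O[C@@H](n4cc(F)c(=O)[nH]c4=O)C[C@@H]3OC(=O)c3ccccc3)ccc21` gives 13000 nM. Both of these numbers lie higher than that of compound 1, beyond the scatter, so compound 1 is the strongest inhibitor of the set.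

Next in line is compound 4 `O=c1[nH]c(=O)n([C@H]2C[C@H](O)[C@@H](COP(=O)(O)Oc3ccc4ncccc4c3)O2)cc1F`, which follows from compound 1 through one change: hydrogen in place of benzoyl on an oxygen on a saturated carbon. In words, hydrogen stands in place of benzoyl on an oxygen on a saturated carbon, so benzoyloxy becomes hydroxy. Going by the values given here, all three measured compounds carry the benzoyl group, and none shows the hydroxy form, so the data hold no direct precedent for this change.

Compound 1 at 1300 nM sits at the low end of the measured span, which leaves more room for a move upward than downward. A modest rise is therefore expected in this assay, meaning somewhat weaker inhibition, though a result within the scatter of compound 1 would not surprise. The estimated step is a 2.3-fold higher number from compound 1 to compound 4 (0.36 log units; beyond the scatter). For compound 4 the estimated value is 3000 nM, with an expected range of 800 nM to 12000 nM.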

Compound 4, half-maximal inhibitory concentration: 1900 nM
Estimate against measurement, compound 4: 1.6-fold (0.20 log units) above, and the stated range covers the measured number.
By their numbers in this assay, from the lowest: compounds 1 and 4 (each within the scatter of the next); then compounds 3 and 2 (each within the scatter of the next).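

In this assay, this is the only variation at this position among the compounds shown, and a 1.5-fold higher number from compound 1 to compound 4 (0.16 log units; within the scatter) places benzoyloxy and hydroxy within the scatter of each other. On this read-out, benzoyl on this oxygen on a saturated carbon can therefore be replaced by hydrogen with no change that can be told apart from repeat-measurement noise, at least with the partner on the phosphate that compound 1 and compound 4 share. No measurement at hand bears on why the number holds once the benzoyl group is gone.

Whether the same replacement would behave alike with the different phosphate partners of compound 2 and compound 3 stays open, as these two compounds carry benzoyl and the pairs that would answer this are absent from the compounds shown. Also open, from the compounds shown here alone, is how an acetyl ester, a longer acyl chain or an amine in this place would read against the benzoyloxy and hydroxy forms.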